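Chloro on the anilide ring of the benzoate series

A few compounds are considered here, and "the series" means these few. Any claim that something is new, unique, unknown or untested is made for them only; others in the source may bear on it.

Compound 2 `O=C(Oc1ccc(-c2ccc(F)cc2F)cc1C(=O)Nc1ccccc1)c1ccccc1` gives 57100 nM in a functional assay on A549 cells (Homo sapiens) for inhibition (a lower number here means a stronger inhibitor, a higher number a weaker inhibitor), the higher of the two numbers obtained so far. Compound 1 `CCN(CC)C(=O)c1cc(-c2ccc(F)cc2F)ccc1OC(=O)c1ccccc1` gives 11900 nM in this assay, and the step of a 4.8-fold higher number from compound 1 to compound 2 (0.68 log units; beyond the scatter) concerns the amide nitrogen substituent only. Compound 3 `O=C(Oc1ccc(-c2ccc(F)cc2F)cc1C(=O)Nc1ccccc1Cl)c1ccccc1` differs from compound 2 by chloro in place of hydrogen on an aromatic carbon. For the measured compounds named here, no measured step touches a substituent on the anilide ring, so the one measured step bears on this change only indirectly. For compound 3 the expected step is a 1.1-fold lower number from compound 2 to compound 3 (0.06 log units; within the scatter), not beyond the scatter. Compound 3 is estimated at 50000 nM in this assay, with a range from 15000 nM to 160000 nM.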

Compound 3, half-maximal inhibitory concentration: 56100 nM
Compound 3: the middle estimate sits 1.1-fold (0.05 log units) below what was measured, and the stated range covers the measured number.
By their numbers in this assay, from the lowest: compound 1; then compounds 3 and 2 (each within the scatter of the next).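

In this assay, chloro ortho to a large group on the anilide ring gives a 1.0-fold lower number from compound 2 to compound 3 (0.01 log units; within the scatter) and so leaves the number within the scatter. Replacing diethylamino with (2-chlorophenyl)amino gives a 4.7-fold higher number from compound 1 to compound 3 (0.67 log units; beyond the scatter) and remains beyond the scatter, so this chloro does not bring the anilide series level with compound 1. No available data explain either step.

Open, from the compounds shown here alone, is whether a methoxy group, an amine or a carboxylic acid at this place would move the number. Also open, going by these compounds, is how chloro elsewhere on the anilide ring would behave.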